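This account rests on a few compounds, and the source may have more. Where it says the series, first, only, none or still open, it means among the compounds named here.

Compound 1, `CCc1nc2ccc(Cl)cn2c1C(=O)NCc1ccc2[nH]ccc2c1`: in an ADME assay on microsomes from liver (Homo sapiens) for metabolic stability (on this read-out lower numbers stand for a shorter-lived compound and higher numbers for a longer-lived compound), compound 1 gives 0.147 h.
Compound 2, `CCc1nc2cc(Cl)ccn2c1C(=O)NCc1ccc2oc(-c3ccc(OC(F)(F)F)cc3)nc2c1`: in this assay compound 2 gives only the limit > 2 h.
Compound 3, `CCc1nc2ccc(Cl)cn2c1C(=O)NCc1ccc2oc(-c3ccc(OC(F)(F)F)cc3)nc2c1`: in this assay compound 3 gives only the limit > 2 h.

Compound 3 therefore stands at the upper edge of what this assay can report, a limit rather than a number, and it shares that position with compound 2 (the limit of > 2 h in this assay, at which 2 of the 3 values shown sit). Among the compounds with values here, the only measured step, a step that the two limits leave unreadable from compound 2 to compound 3, has both of its ends at that limit, and its size cannot be read. Within the data shown here, compound 1, which carries a smaller group on the carbonyl carbon, gives a plain number that falls well short of the limit, but no step between compound 1 and compound 3 has been worked out.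

Compound 4, `CCc1nc2ccc(Cl)cn2c1C(=O)NCc1ccc2oc(C3CCCCC3)nc2c1`, differs from compound 3 by cyclohexyl in place of 4-(trifluoromethoxy)phenyl on an aromatic carbon. Among the measured compounds shown here, no measured step covers this kind of exchange, so the expectation rests on compound 3 alone and is uncertain. The step from compound 3 to compound 4 is expected to be an at least 1.6-fold lower number from compound 3 to compound 4 (0.22 log units; that floor lies within the scatter). Compound 4 is estimated to give 1.2 h, within a range of 0.4 h to 2.5 h.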

Compound 4, half-life: 0.283 h
Estimate against measurement, compound 4: 4.2-fold (0.63 log units) above; the whole stated range lies above it.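

The exchange of 4-(trifluoromethoxy)phenyl for cyclohexyl, on an aromatic carbon of the five-membered aromatic ring, gives an at least 7.0-fold lower number from compound 3 to compound 4 (0.84 log units; beyond the scatter) in this assay. Within the data shown here, this is the first readable step at this position, and it shows that the half-life depends on the group placed there. The step gives only a floor and not a full size, because compound 3 sits at a limit of the assay rather than at a number: the limit of > 2 h in this assay, at which 2 of the 4 values shown sit.

The exchange removes both the aromatic ring and the trifluoromethoxy group at once, so the compounds shown cannot tell which of the two the drop in half-life follows. A plain phenyl or a 4-methoxyphenyl at this position would begin to separate them.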